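Swapping the urea aryl group in a hedgehog-pathway reporter series

A few compounds are considered here, and "the series" means these few. Any claim that something is new, unique, unknown or untested is made for them only; others in the source may bear on it.

Measured compounds:
compound 1, `O=C(Nc1ccccc1Cl)N1CCN(c2nc(-c3ccc4ccccc4n3)no2)CC1`: 140 nM
compound 2, `Cc1noc(C)c1NC(=O)N1CCC(c2nc(-c3ccc4ccccc4n3)no2)CC1`: 3000 nM
compound 3, `COc1ccccc1N(C)C(=O)N1CCC(c2nc(-c3ccc4ccccc4n3)no2)CC1`: 3100 nM

In a functional assay on Shh Light II cells (Mus musculus) for inhibition, read by a luciferase reporter (a higher number here means a weaker inhibitor, a lower number a stronger inhibitor), compound 3 gives the highest of the three numbers. Its nearest neighbour is compound 2, which lies within the scatter of it, as the step of a 1.0-fold higher number from compound 2 to compound 3 (0.01 log units; within the scatter) shows; compound 1 stands a long way lower. Compound 4, `O=C(Nc1cccnc1Cl)N1CCC(c2nc(-c3ccc4ccccc4n3)no2)CC1`, is the next variation on the shared core of compound 3. The change is (2-chloropyridin-3-yl)amino in place of (2-methoxyphenyl)(methyl)amino on a carbonyl carbon.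

Going by the values given here, only one measured step touches the carbonyl substituent directly, a 1.0-fold higher number from compound 2 to compound 3 (0.01 log units; within the scatter), and it shows that exchanging one amino group for another left the number unmoved. Among the compounds with values here, compound 1, however, carries an amino group with a hydrogen-bond donor and a chlorine on its ring, as the entering group of compound 4 does, and compound 1 gives 140 nM on a different core, so no step to it is available. On balance a drop in the number is expected for compound 4, with the size of a 3.4-fold lower number from compound 3 to compound 4 (0.54 log units; beyond the scatter) uncertain. Compound 4 is therefore estimated at 900 nM, within 250 nM to 3500 nM.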

Compound 4, half-maximal inhibitory concentration: 1600 nM
For compound 4 the middle estimate is 1.8-fold (0.25 log units) below the measured one; the measured number falls inside the stated range.
By their numbers in this assay, from the lowest: compound 1; then compounds 4, 2 and 3 (each within the scatter of the next).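

In this assay, the (2-chloropyridin-3-yl)amino group gives a 1.9-fold lower number from compound 3 to compound 4 (0.29 log units; within the scatter), and the same comparison against the 3,5-dimethyl-1,2-oxazol-4-yl compound gives a 1.9-fold lower number from compound 2 to compound 4 (0.27 log units; within the scatter). Three different groups on this carbonyl carbon, including the entering group with its hydrogen-bond donor and chlorine, therefore leave the number within the scatter on the shared core, so a donor and a chlorine on the group do not by themselves reproduce the number of compound 1, 140 nM. Nothing available here bears on why these groups give such similar numbers.

Going by these compounds, compound 1 differs from compound 4 in more than one place, so it remains open whether its separation from the others belongs to its core or to its urea group. On these data alone, it is also open whether an unsubstituted phenyl ring or a longer alkyl chain on the amide-type nitrogen would move the number beyond the scatter.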